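From methyl to hydroxy in a small compound pair

A few compounds are considered here, and "the series" means these few. Any claim that something is new, unique, unknown or untested is made for them only; others in the source may bear on it.

- Compound 1 `CN(C)/C=C/C(=O)c1nn(-c2ccccc2)c(-c2ccccc2)c1C#N` gives 30200 nM
- Compound 2 `Cc1nnc(-c2nn(-c3ccccc3)c(-c3ccccc3)c2C#N)c2cn(-c3ccccc3)nc12` gives 9140 nM

In a functional assay on T47D cells (Homo sapiens) for inhibition, read by sulforhodamine B assay, with a stated time of 48 h (on this read-out lower numbers stand for stronger inhibition of growth and higher numbers for weaker inhibition of growth), compound 2 gives 9140 nM and stands lowest of the two numbers, with compound 1 higher by a margin beyond the usual scatter. The next compound to be tested is compound 3 `N#Cc1c(-c2nnc(O)c3nn(-c4ccccc4)cc23)nn(-c2ccccc2)c1-c1ccccc1` which differs from compound 2 in one place: it has hydroxy in place of methyl on an aromatic carbon and keeps the rest of the structure. Going by the values given here, no measured pair in this small set shows such an exchange, so the expectation is tentative. In this assay a small step towards weaker inhibition of growth, not clearly beyond the scatter, is expected, with a 1.8-fold higher number from compound 2 to compound 3 (0.24 log units; within the scatter) as the estimated size. For compound 3 the estimated value is 16000 nM with an expected range from 5000 nM to 50000 nM as the likely span.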

Compound 3, concentration for 50% growth inhibition: 2950 nM
Compound 3: the middle estimate sits 5.4-fold (0.73 log units) above what was measured, and the stated range ends above it.
By their numbers in this assay, from the lowest: compound 3; then compound 2; then compound 1.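

In this assay, going by these compounds alone, the exchange of methyl for hydroxy on an aromatic carbon gives a 3.1-fold lower number from compound 2 to compound 3 (0.49 log units; beyond the scatter) and is the first single-place change in this set that can be read. It shows that methyl is not required at this position, on the six-membered aromatic ring with 2 nitrogen and next to the ring nitrogen, and that hydroxy there goes with stronger inhibition of growth in these cells. Nothing available bears on why the number falls with this change.

The compounds shown leave open whether an amine or a methoxy group at this position would match hydroxy, or whether the gain is particular to hydroxy. They also leave open whether the exchange would give a step of similar size if the nitrile on the shared core gave way to a carboxylic acid.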